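The compounds below may be only part of what the source reports. "The series", "measured", "known", "first", "only" and "open" are said of these compounds alone.

Measured so far in a functional assay on MDA-MB-231 cells (Homo sapiens) for inhibition, read by MTT assay, with a stated time of 48 h; on this read-out lower numbers stand for stronger inhibition of growth and higher numbers for weaker inhibition of growth:
- compound 1 `S=C(NCc1ccccc1)Nc1ccc2ncnc(Nc3ccc(Oc4ccccc4)cc3)c2c1`: 6800 nM
- compound 2 `S=C(Nc1ccccc1)Nc1ccc2ncnc(Nc3cccc(Br)c3)c2c1`: 10000 nM

Among the compounds with values here, compound 2 stands within the usual scatter of compound 1, so these two values set no order between the compounds.

Compound 3 `Oc1ccc(NC(=S)Nc2ccc3ncnc(Nc4cccc(Br)c4)c3c2)cc1` is compound 2 with one change, hydroxy in place of hydrogen on an aromatic carbon, para to a large group, so that phenyl becomes 4-hydroxyphenyl.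

Within the data shown here, no measured pair shows this change, so the expectation rests only on the narrow span of the two values in this assay. The expected 1.4-fold lower number from compound 2 to compound 3 (0.15 log units; within the scatter) is small, leaning towards stronger inhibition of growth and not clearly beyond the scatter. Compound 3 is estimated at 7000 nM, with an expected range from 2500 nM to 20000 nM.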

Compound 3, concentration for 50% growth inhibition: 17300 nM
For compound 3 the middle estimate is 2.5-fold (0.39 log units) below the measured one; the measured number falls inside the stated range.
By their numbers in this assay, from the lowest: compounds 1, 2 and 3 (each within the scatter of the next, the first and the last beyond it).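

In this assay, hydroxy in place of hydrogen on an aromatic carbon, para to a large group, gives a 1.7-fold higher number from compound 2 to compound 3 (0.24 log units; within the scatter). Within the data shown here, this is the first pair that differs in one place, and with everything else held fixed, the read-out does not separate 4-hydroxyphenyl from phenyl at this position. Nothing at hand offers an explanation for this result.

The compounds shown leave open whether an amine, a carboxylic acid or a methoxy group at this same place would stand apart from hydrogen, and whether hydroxy on another carbon of that ring would read differently. They also leave open whether the same change would read alike with the other parts of compound 1.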